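Furan-2-yl to 2-Chlorophenyl: An Expected Gain in Cytotoxicity

The compounds below may be only part of what the source reports. "The series", "measured", "known", "first", "only" and "open" are said of these compounds alone.

Compound 3 `Clc1ccc(-c2cc(-c3ccco3)nc(-c3cccs3)c2)o1` stands at the edge of what a functional assay on HCT-15 cells (Homo sapiens) for cytotoxicity, in the presence of a further agent that is not named here (a higher number here means a weaker inhibitor, a lower number a stronger inhibitor), can report: in this assay compound 3 gives > 50000 nM, which is a limit and not a number. Compound 2 `Clc1ccc(-c2cc(-c3cccnc3)nc(-c3cccs3)c2)o1` gives 1240 nM in this assay, and compound 1 `Clc1ccc(-c2cc(-c3ccsc3)nc(-c3ccccc3Cl)c2)o1` gives 4570 nM. The measured step that bears on this position is an at least 40-fold higher number from compound 2 to compound 3 (1.60 log units; beyond the scatter), ending at the limit of > 50000 nM in this assay, at which 1 of the 3 values shown sits. Compound 4 `Clc1ccc(-c2cc(-c3cccs3)nc(-c3ccccc3Cl)c2)o1` arises from compound 3 by 2-chlorophenyl in place of furan-2-yl on an aromatic carbon. Compound 1 carries the same 2-chlorophenyl group at that position and returns a measurable number, 4570 nM, so a reversal of the loss seen in an at least 40-fold higher number from compound 2 to compound 3 (1.60 log units; beyond the scatter) is expected. The step is expected to be an at least 14-fold lower number from compound 3 to compound 4 (1.15 log units; beyond the scatter), large and toward stronger inhibition. For compound 4 the estimate is 3500 nM, within 1000 nM to 15000 nM.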

Compound 4, half-maximal inhibitory concentration: 6190 nM
The estimate for compound 4 lay 1.8-fold (0.25 log units) below the measured number; measured number inside the range.
By their numbers in this assay, from the lowest: compound 2; then compounds 1 and 4 (each within the scatter of the next). At a limit, above all of these: compound 3.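

In this assay the change to 2-chlorophenyl gives an at least 8.0-fold lower number from compound 3 to compound 4 (0.90 log units; beyond the scatter) and so turns this position from a limit into a measurable number. Compound 3 itself stands at a limit: the limit of > 50000 nM in this assay, at which 1 of the 4 values shown sits. The new group does not match pyridin-3-yl, as a 5.0-fold higher number from compound 2 to compound 4 (0.70 log units; beyond the scatter) shows, and with 2-chlorophenyl in place, thiophen-2-yl and thiophen-3-yl cannot be told apart, as a 1.4-fold higher number from compound 1 to compound 4 (0.13 log units; within the scatter) shows.

As far as these compounds go, whether an amine or a carboxylic acid at this position would match pyridin-3-yl remains open. So does whether a chlorine elsewhere on the phenyl ring would serve equally well.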